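The compounds below may be only part of what the source reports. "The series", "measured", "known", "first", "only" and "open" are said of these compounds alone.

Measured so far in a functional assay on HeLa cells (Homo sapiens); a higher number here means that more compound is needed for the effect, a lower number that less compound is needed:

Compound 1 `NC(=O)c1cc(CCl)[nH]n1`: > 100 ug/mL (a limit)
Compound 2 `CCOC(=O)c1cc(CI)[nH]n1`: > 100 ug/mL (a limit)
Compound 3 `CCOC(=O)c1cc(CCl)nn1C1O[C@@H](COC(C)=O)[C@H](OC(C)=O)[C@@H](OC(C)=O)[C@@H]1OC(C)=O`: 40 ug/mL

Compound 3 is the only one of the three with a true number, 40 ug/mL. Compound 1 and compound 2 both stop at the limit of > 100 ug/mL in this assay, at which 2 of the 3 values shown sit, so neither offers a number to compare with.

The next compound to be measured is compound 4 `CCOC(=O)c1cc(CCl)nn1C1O[C@H](COC(C)=O)[C@@H](OC(C)=O)[C@H](OC(C)=O)[C@H]1OC(C)=O`. Its difference from compound 3 is purely one of spatial arrangement: the two compounds have the same atoms and bonds; at least one stereo element is drawn with a configuration in one of them and without one in the other: 4 of 5 stereo elements differ; a stereocentre at a saturated ring carbon is drawn S in compound 3 and R in compound 4; a stereocentre at a saturated ring carbon is drawn S in compound 3 and R in compound 4; a stereocentre at a saturated ring carbon is drawn R in compound 3 and S in compound 4; a stereocentre at a saturated ring carbon is drawn S in compound 3 and R in compound 4. Nothing leaves and nothing enters, since the two compounds have the same atoms and bonds. Only the drawn configuration at saturated ring carbons changes.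

Within the data shown here, no measured pair here shows what such a change does in this assay, so any forecast is loose. The expectation therefore starts from compound 3 at 40 ug/mL. The expected shift is small, slightly toward more compound being needed and no larger than the usual scatter: a 1.3-fold higher number from compound 3 to compound 4 (0.10 log units; within the scatter). A result that reaches only the limit of the assay remains possible. For compound 4 the estimate is 50 ug/mL, with an expected range from 20 ug/mL to 100 ug/mL.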

Compound 4, concentration for half-maximal effect: > 100 ug/mL
Compound 4: a limit, no number (the forecaster's own chance of this, stated with the estimate: 25%); middle value at least 2.0-fold (0.30 log units) away from the limit.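

In this assay, a change that removes and adds no atoms still has a clear effect: moving only the drawn configuration at the saturated ring carbons gives an at least 2.5-fold higher number from compound 3 to compound 4 (0.39 log units; beyond the scatter), a step beyond the usual scatter and the first reading available from two compounds that differ in one place. Compound 4 gives > 100 ug/mL, which is a limit of the assay and not a number, so the step has a known lower bound but no known full size. One point limits how exactly the change can be described: the fact that one of compounds 3 and 4 is drawn with a defined configuration and the other without, at the place where they differ

Four stereocentres on the saturated ring change together, so these compounds cannot show whether a single one of them accounts for the step or whether several contribute. Also open, as far as these compounds go, is how the result would respond to a change of groups rather than arrangement, such as free hydroxyl groups in place of the acetate esters on the ring of compound 3, or an amine in place of the chlorine of its chloromethyl group.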